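Chloro replacement from compound 1 to compound 4

The source may hold more compounds than are shown below. What is called first, only, known or untested is meant among the compounds shown, and "the series" means these compounds.

Measured in an ADME assay on MRC5 cells (Homo sapiens) for cytotoxicity, read by neutral red uptake (a higher number here means that more compound is tolerated, a lower number that less compound is tolerated), so far:
- compound 1 `O=c1[nH]c(SCc2cc([N+](=O)[O-])cc([N+](=O)[O-])c2)nc2ccccc12` gives > 64000 nM as a limit
- compound 2 `O=c1[nH]c(SCc2cc([N+](=O)[O-])cc(C(F)(F)F)c2)nc2ccccc12` gives > 64000 nM as a limit
- compound 3 `O=c1[nH]c(SCc2cc([N+](=O)[O-])cc([N+](=O)[O-])c2)nc2ccc(Cl)cc12` gives > 64000 nM as a limit

Compound 1 stands at a limit and not at a number, and so do the other two measured compounds (the limit of > 64000 nM in this assay, at which 3 of the 3 values shown sit). Compound 4 `O=c1[nH]c(SCc2cc([N+](=O)[O-])cc([N+](=O)[O-])c2)nc2cc(Cl)ccc12` has not been measured. It differs from compound 1 by chloro in place of hydrogen on an aromatic carbon.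

The measured step closest to this change is also chloro in place of hydrogen on an aromatic carbon (a step that the two limits leave unreadable from compound 1 to compound 3). The other measured step is trifluoromethyl in place of nitro on an aromatic carbon (a step that the two limits leave unreadable from compound 1 to compound 2) and bears on the change less directly. Neither step has a readable size. Compound 3, which carries a chloro, is still a limit (> 64000 nM).

No step beyond the scatter is therefore expected in this assay for this change, and a second report as a limit is the likeliest outcome. The expected step is only an estimate (a number no higher from compound 1 to compound 4 (the limit leaves the size open)). For compound 4 the estimated value is 64000 nM (expected range 30000 nM to 64000 nM).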

Compound 4, half-maximal cytotoxic concentration: > 64000 nM
Compound 4: a limit, no number (the forecaster's own chance of this, stated with the estimate: 75%); the middle value lies on the limit itself.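

No step can be read in this assay between compound 1 and compound 4, or between compound 1 and either compound 2 or compound 3, since each result is a limit and not a number: the limit of > 64000 nM in this assay, at which 4 of the 4 values shown sit.

The compounds shown leave open how far any of these four lies from that limit, and whether chloro in place of hydrogen on an aromatic carbon or trifluoromethyl in place of nitro on an aromatic carbon shifts the read-out in this assay at all.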